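From Chloro to Piperidinylmethyl: Expected Clearance of Compound 4

A few compounds are considered here, and "the series" means these few. Any claim that something is new, unique, unknown or untested is made for them only; others in the source may bear on it.

In an ADME assay on microsomes from liver (Mus musculus) for metabolic stability, read by LC-MS, tested at 1 uM (on this read-out lower numbers stand for slow clearance and higher numbers for fast clearance), three compounds have been measured:
compound 1 `CCOC(=O)C1=C(C)N/C(=C/c2cc(C)n(-c3cccc(C(F)(F)F)c3)c2C)C1=O` gives 97 mL.min-1.g-1;
compound 2 `CCOC(=O)C1=C(O)/C(=C\c2cc(C)n(-c3ccc(F)cc3)c2C)N=C1C` gives 94 mL.min-1.g-1;
compound 3 `CCOC(=O)C1=C(C)N/C(=C/c2cc(C)n(-c3ccc(Cl)cc3)c2C)C1=O` gives 72 mL.min-1.g-1.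

Compound 3 has the lowest of the three numbers, but its gaps to compound 2 and to compound 1 both lie within the scatter, so no order among them can be claimed. Within the data shown here, the one single-point step among them, a 1.3-fold lower number from compound 1 to compound 3 (0.13 log units; within the scatter), changes the aryl group on the ring nitrogen and stays within the scatter.

Compound 4 `CCOC(=O)C1=C(C)N/C(=C/c2cc(C)n(-c3ccc(CN4CCCCC4)cc3)c2C)C1=O` differs from compound 3 by (piperidin-1-yl)methyl in place of chloro on an aromatic carbon. Among the measured compounds shown here, no measured step introduces a group of this kind, so the data give no direct guide. The change is expected to produce a 1.2-fold higher number from compound 3 to compound 4 (0.07 log units; within the scatter), with a wide range. Compound 4 is therefore estimated at 85 mL.min-1.g-1, between 35 mL.min-1.g-1 and 200 mL.min-1.g-1.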

Compound 4, intrinsic clearance in microsomes: 60 mL.min-1.g-1
Estimate against measurement, compound 4: 1.4-fold (0.15 log units) above, within the range that was stated.
By their numbers in this assay, from the lowest: compounds 4, 3, 2 and 1 (each within the scatter of the next).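

In this assay, (piperidin-1-yl)methyl in place of chloro on this aromatic carbon, para to a large group, gives a 1.2-fold lower number from compound 3 to compound 4 (0.08 log units; within the scatter). The earlier compounds shown here carried only small groups on this aryl ring, and this result shows that a much larger amine-bearing group with a six-membered non-aromatic ring can stand here with no change beyond the scatter. Nothing available explains this outcome.

Going by these compounds, whether a morpholine, a primary amine or a carboxylic acid at this place would read the same remains open. So does whether a longer chain between the ring and the amine would leave the number within the scatter.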